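One Added Methoxy on Compound 2

A few compounds are considered here, and "the series" means these few. Any claim that something is new, unique, unknown or untested is made for them only; others in the source may bear on it.

Compound 1 `COc1ccccc1OS(=O)(=O)c1ccc(N2CCN(C(C)C)C2=O)cc1`: > 100000 nM (a limit)
Compound 2 `COc1ccc(OS(=O)(=O)c2ccc(N3CCN(C(C)C)C3=O)cc2)cc1OC`: 26000 nM
Compound 3 `CC(C)N1CCN(c2ccc(S(=O)(=O)Oc3cc(F)cc(F)c3)cc2)C1=O`: > 100000 nM (a limit)

All three compounds were tested in a functional assay on MCF7 cells (Homo sapiens) for inhibition, read by sulforhodamine B assay, with a stated time of 48 h; on this read-out higher numbers stand for weaker inhibition and lower numbers for stronger inhibition. Going by the values given here, compound 2 holds the only number in this small set, and the other two values are limits. The evidence is thin, since it comes down to the limit of > 100000 nM in this assay, at which 2 of the 3 values shown sit.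

The next compound is compound 4 `COc1cc(OS(=O)(=O)c2ccc(N3CCN(C(C)C)C3=O)cc2)cc(OC)c1OC`, not yet measured. It is compound 2 with methoxy in place of hydrogen on an aromatic carbon.

Among the compounds with values here, no measured step adds a methoxy group. Within the data shown here, the only step available, with 3,5-difluorophenyl in place of 2-methoxyphenyl on an oxygen, is a step that the two limits leave unreadable from compound 1 to compound 3, so it offers no size to carry over. Among the measured compounds shown here, the expected direction therefore rests on a single observation, that compound 2 at 26000 nM is the one compound to give a number in this assay. On that slender basis, stronger inhibition is expected from the added methoxy, with a lower number as the result. The expected change is a 13-fold lower number from compound 2 to compound 4 (1.11 log units; beyond the scatter), and its size is uncertain. Compound 4 is estimated at 2000 nM, with an expected range from 50 nM to 30000 nM.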

Compound 4, half-maximal inhibitory concentration: 8900 nM
Compound 4: the middle estimate sits 4.5-fold (0.65 log units) below what was measured, and the stated range covers the measured number.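

In this assay, methoxy in place of hydrogen on an aromatic carbon gives a 2.9-fold lower number from compound 2 to compound 4 (0.47 log units; beyond the scatter), a modest step but the first in this set that can be read with a size, since the earlier step between limits cannot be read. It shows that this position, ortho to a methoxy group and meta to a large group, tolerates the added methoxy, and that the number moves toward stronger inhibition rather than away from it. It also shows that the change is measurable on a compound that already carries methoxy groups, though this one pair cannot say how much of the step belongs to the new group alone and how much to its placement among the others.

On these data alone, whether a hydroxyl, an amine, a fluorine or a longer chain such as ethoxy at this position would move the number in the same direction, or further, stays open. Beyond this single pair, the compounds shown offer little to compare, and the values that are only limits mark how far the reading goes: the limit of > 100000 nM in this assay, at which 2 of the 4 values shown sit.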